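The source may hold more compounds than are shown below. What is called first, only, known or untested is meant among the compounds shown, and "the series" means these compounds.

Compound 1, `O=C(N/N=C/c1ccc(O)c(O)c1)c1ccc(-c2nc3ccccc3s2)cc1`, gives 15100 nM in an assay on isolated protein for inhibition of Maltase-glucoamylase (Homo sapiens), with a stated time of 15 min; a lower number here means a stronger inhibitor, a higher number a weaker inhibitor.
Compound 2, `O=C(N/N=C/c1ccc(O)cc1O)c1ccc(-c2nc3ccccc3s2)cc1`, gives 5580 nM.
Compound 3, `O=C(N/N=C/c1ccc([N+](=O)[O-])cc1)c1ccc(-c2nc3ccccc3s2)cc1`, gives 26400 nM.

Among these three, compound 3 stands at the highest number, which means the weakest inhibition of the set. Its nearest neighbour is compound 1, and the step of a 1.7-fold higher number from compound 1 to compound 3 (0.24 log units; within the scatter) lies within the scatter, so the two cannot be told apart. Its furthest neighbour is compound 2, and the step of a 4.7-fold higher number from compound 2 to compound 3 (0.67 log units; beyond the scatter) is modest but real.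

Compound 4, `O=C(N/N=C/c1ccncc1)c1ccc(-c2nc3ccccc3s2)cc1`, changes the same part of the molecule that varies across the measured set: pyridin-4-yl in place of 4-nitrophenyl on a carbon with a double bond to nitrogen. The two steps that bear on this position, a 1.7-fold higher number from compound 1 to compound 3 (0.24 log units; within the scatter) and a 4.7-fold higher number from compound 2 to compound 3 (0.67 log units; beyond the scatter), both swap one aromatic group for another there and both gave at most modest changes. Among the compounds with values here, no measured compound carries a pyridin-4-yl group, so there is no direct precedent. Given the small steps seen so far at this position, compound 4 is expected to sit near compound 3, with the step of a 1.1-fold higher number from compound 3 to compound 4 (0.06 log units; within the scatter) judged as little or no change beyond the scatter. Compound 4 is therefore estimated at 30000 nM, in a range from 10000 nM to 90000 nM.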

Compound 4, half-maximal inhibitory concentration: "not active" (no number reported)
The entry for compound 4 holds no number, and the estimate cannot be compared.
By their numbers in this assay, from the lowest: compound 2; then compounds 1 and 3 (each within the scatter of the next).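

Within the data shown here, compound 4 is recorded as not active, with no number, so no step between compound 4 and compound 3, or any other compound, can be read. The compounds shown leave open how much weaker, if at all, compound 4 is than compound 3. Nothing measured here explains this entry.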